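Methylsulfonyl in place of trifluoromethoxy on a benzamide

The source may report more compounds than this note shows. Statements on the series, on what has been measured and on what is new or still open speak of the compounds shown alone.

Measured compounds:
compound 1, `CC(C)(C)c1ccc(C(=O)NCc2ccc(OC(F)(F)F)cc2)cc1`: 160 nM
compound 2, `CC(C)(C)c1ccc(C(=O)NCc2ccc(C(=O)O)c(Cl)c2)cc1`: 8.8 nM
compound 3, `Cc1ccc(C(=O)NCc2ccc(C(=O)O)cc2)cc1C`: 320 nM

The three compounds were tested in an assay on HeLa cells with Bile acid receptor (Homo sapiens) as the target, read by a luciferase reporter, with a stated time of 24 h; a lower number here means that less compound is needed, a higher number that more compound is needed for the effect. Compound 1 gives 160 nM there, which sits within the scatter of the value of compound 3, so the two cannot be told apart. Compound 2, with its carboxylic acid and chloro substituents, gives 8.8 nM, a clearly lower number that lies beyond the scatter from compound 1.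

The next compound, compound 4, `CC(C)(C)c1ccc(C(=O)NCc2ccc(S(C)(=O)=O)cc2)cc1`, has not yet been measured in this assay. Going by the values given here, it differs from compound 1 in a single place: methylsulfonyl in place of trifluoromethoxy on an aromatic carbon The change is from one uncharged group to another, so nothing among the measured compounds points to a shift as large as that between compound 1 and compound 2. The step in this assay is expected to be a 1.6-fold higher number from compound 1 to compound 4 (0.19 log units; within the scatter), small and in either direction, most likely not beyond the scatter. Compound 4 is therefore estimated at 250 nM, with a range from 60 nM to 1000 nM.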

Compound 4, half-maximal effective concentration: 3800 nM
Beside the measured number, compound 4's estimate is 15-fold (1.18 log units) below it; the whole stated range lies below it.
By their numbers in this assay, from the lowest: compound 2; then compounds 1 and 3 (each within the scatter of the next); then compound 4.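

At this position, on an aromatic carbon para to a large group, the exchange of one group with no net charge for another is not a neutral swap: methylsulfonyl in place of trifluoromethoxy gives a 24-fold higher number from compound 1 to compound 4 (1.38 log units; beyond the scatter) in this assay. Going by these compounds alone, this is the first step between compounds differing in one place, and it shows that the number responds strongly to what sits here, even though both groups have no net charge and neither is a hydrogen-bond donor. Nothing available explains why the step is this large.

The compounds shown leave open whether a methoxy, a trifluoromethyl or a sulfonamide group at this place would give a number close to that of compound 1 or of compound 4. They also leave open whether the same change would have a similar effect on another core.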